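The source may hold more compounds than are shown below. What is called first, only, known or untested is meant among the compounds shown, and "the series" means these compounds.

Among the compounds with values here, in a functional assay on LoVo cells (Homo sapiens) for inhibition, read by MTT assay, with a stated time of 24 h (on this read-out lower numbers stand for stronger inhibition and higher numbers for weaker inhibition), compound 1 `CC1(C)[C@H]2CC[C@]1(C)N(Cc1cn(-c3ccccc3C#N)nn1)C(=O)C2` gives 140 nM and compound 2 `CC1(C)[C@H]2CC[C@]1(C)N(Cc1cn(-c3cccc(C#N)c3)nn1)C(=O)C2` gives 320 nM, the higher of the two numbers so far. Compound 3 `CC1(C)[C@H]2CC[C@]1(C)N(Cc1cn(-c3ccccc3F)nn1)C(=O)C2` follows from compound 2 with 2-fluorophenyl in place of 3-cyanophenyl on an aromatic nitrogen. Within the data shown here, the only measured step bearing on this is a 2.3-fold higher number from compound 1 to compound 2 (0.36 log units; beyond the scatter), which is modest. Among the measured compounds shown here, compound 3 carries 2-fluorophenyl where compound 1, at 140 nM, carries 2-cyanophenyl, but no fluorinated analogue has been measured, so only a modest move to a lower number is expected. The expected change is a 1.5-fold lower number from compound 2 to compound 3 (0.16 log units; within the scatter). For compound 3 the estimated value is 220 nM, with a range of 70 nM to 650 nM.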

Compound 3, half-maximal inhibitory concentration: 40 nM
Compound 3: middle estimate off by 5.5-fold (0.74 log units), on the high side, and the stated range ends above it.
By their numbers in this assay, from the lowest: compound 3; then compound 1; then compound 2.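

Fluoro in place of cyano on an aromatic carbon gives a 3.5-fold lower number from compound 1 to compound 3 (0.54 log units; beyond the scatter), so the identity of the group matters here, not only where a nitrile sits on the phenyl ring. Across both changes, 2-fluorophenyl in place of 3-cyanophenyl on the aromatic nitrogen gives an 8.0-fold lower number from compound 2 to compound 3 (0.90 log units; beyond the scatter), the largest step in the series so far. No measured evidence accounts for either step.

As far as these compounds go, it remains open whether this effect is specific to fluoro, or would also appear with chloro, methoxy or an unsubstituted phenyl on the same nitrogen. From the compounds shown here alone, how fluoro behaves elsewhere on the phenyl ring, and how the shared core responds to change, also remain open.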